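A few compounds are considered here, and "the series" means these few. Any claim that something is new, unique, unknown or untested is made for them only; others in the source may bear on it.

Measured so far:
compound 1, `Cc1ccc(Nc2ccnc(NCCCNc3ccnc4cc(Cl)ccc34)n2)cc1`: 18500 nM
compound 2, `COc1ccc(Nc2ccnc(NCCCNc3ccnc4cc(Cl)ccc34)n2)cc1`: 13300 nM

In an ADME assay on Vero cells (Chlorocebus sabaeus) for cytotoxicity, read by neutral red uptake, with a stated time of 72 h (a lower number here means a stronger inhibitor, a higher number a weaker inhibitor), compound 2 stands beside compound 1, the two numbers lying within the scatter of each other. Compound 3, `COc1cc(Nc2ccnc(NCCCNc3ccnc4cc(Cl)ccc34)n2)cc(OC)c1`, has not been measured. The change from compound 2 to compound 3 is 3,5-dimethoxyphenyl in place of 4-methoxyphenyl on a nitrogen on an aromatic ring. Going by the values given here, the only measured step on this part of the molecule is a 1.4-fold lower number from compound 1 to compound 2 (0.14 log units; within the scatter), which exchanged one group on the same ring without moving the number beyond the scatter. The step from compound 2 to compound 3 is therefore expected to be a 1.0-fold lower number from compound 2 to compound 3 (0.01 log units; within the scatter), with no direction beyond the scatter. Compound 3 is estimated at 13000 nM, within 5000 nM to 35000 nM.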

Compound 3, half-maximal inhibitory concentration: 12900 nM
Compound 3: middle estimate off by 1.0-fold (0.00 log units), on the high side; measured number inside the range.
By their numbers in this assay, from the lowest: compounds 3, 2 and 1 (each within the scatter of the next).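

In this assay, putting 3,5-dimethoxyphenyl in place of 4-methoxyphenyl on this nitrogen gives a 1.0-fold lower number from compound 2 to compound 3 (0.01 log units; within the scatter) and putting it in place of 4-methylphenyl gives a 1.4-fold lower number from compound 1 to compound 3 (0.16 log units; within the scatter) on the same nitrogen. Going by these compounds alone, the earlier step exchanged only one group on this ring, whereas these steps show that a ring carrying two methoxy groups also stays within the scatter. Nothing available explains this flat result. Still open, going by these compounds, is whether an amine or a carboxylic acid on this ring would move the number beyond the scatter, and whether a change elsewhere on the shared core, such as a longer chain, would do so.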